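A few compounds are considered here, and "the series" means these few. Any claim that something is new, unique, unknown or untested is made for them only; others in the source may bear on it.

Three compounds share a core built around a five-membered nitrogen ring carrying a carboxymethyl group, attached to an aromatic ring; the rest of each molecule varies. Compound 1 `Cc1ccccc1Cc1ccc(N2CCC[C@H]2CC(=O)O)cc1` is the plainest of them. In a functional assay on cells for agonist activity at Free fatty acid receptor 1 (Mus musculus), read by FLIPR and calcium flux, with a stated time of 100 s (on this read-out lower numbers stand for an effect already at smaller amounts and higher numbers for an effect only at larger amounts of compound), compound 1 gives only a limit, > 33000 nM, and no number. Compound 2 `O=C(O)C[C@@H]1CCCN1c1ccc(Oc2ccc(Cl)cc2Cl)cc1` in this assay gives 3200 nM. Compound 3 `COc1ccc(F)c(-c2ccc(Cc3ccc(N4CCC[C@H]4CC(=O)O)cc3)c(C)c2)c1` in this assay gives 1900 nM. Among the two numbers shown, compound 3 has the lowest, while compound 2 lies within the usual scatter of it, so the two cannot be told apart on these data. Among the compounds with values here, the one step measured in one place is an at least 17-fold lower number from compound 1 to compound 3 (1.23 log units; beyond the scatter); it is large, but it concerns an aromatic position and says nothing about the ring that bears the acid. Compound 4 `COc1ccc(F)c(-c2ccc(Cc3ccc(N4C[C@H](C(F)(F)F)C[C@H]4CC(=O)O)cc3)c(C)c2)c1` takes the next step from compound 3: trifluoromethyl in place of hydrogen on a saturated ring carbon. Within the data shown here, no measured pair shows what such a change does, so the expectation rests on compound 3 alone and is correspondingly uncertain. The estimate is that compound 4 in this assay gives 1900 nM, between 500 nM and 7000 nM, which would mean a step of no change at the digits printed from compound 3 to compound 4 (within the scatter), not beyond the scatter.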

Compound 4, half-maximal effective concentration: 1100 nM
Beside the measured number, compound 4's estimate is 1.7-fold (0.24 log units) above it; the measured number falls inside the stated range.
By their numbers in this assay, from the lowest: compounds 4, 3 and 2 (each within the scatter of the next, the first and the last beyond it). At a limit, above all of these: compound 1.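

This is the first change shown on the saturated ring that bears the carboxymethyl group, as the earlier step concerned an aromatic position. In this assay trifluoromethyl in place of hydrogen on this ring carbon, two ring bonds from the ring nitrogen, gives a 1.7-fold lower number from compound 3 to compound 4 (0.24 log units; within the scatter) and so the two compounds cannot be told apart, which means that a group of 4 heavy atoms can stand here with no loss that these data can detect. No measurement shown speaks to what lies behind this result.

The compounds shown leave open what a methyl, a single fluorine, a hydroxyl or an amine would do on the same ring carbon, and whether trifluoromethyl in the opposite spatial arrangement would give a similar number. They also leave open whether trifluoromethyl at this carbon would give a similar step on compound 2, whose group on the aromatic ring differs from that of compound 3.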